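The source may hold more compounds than are shown below. What is called first, only, known or untested is meant among the compounds shown, and "the series" means these compounds.

Compound 2 `COc1cc2c(Oc3ccc(NC(=O)N/N=C/c4ccc([N+](=O)[O-])cc4)cc3F)ccnc2cc1OCCCN1CCC(C)CC1` gives in a functional assay on HT-29 cells (Homo sapiens) for cytotoxicity, read by MTT assay, with a stated time of 72 h (on this read-out lower numbers stand for stronger inhibition and higher numbers for weaker inhibition), 230 nM, the lowest of the two numbers; compound 1 `COc1ccc(/C=N/NC(=O)Nc2ccc(Oc3ccnc4cc(OCCCN5CCC(C)CC5)c(OC)cc34)c(F)c2)cc1` gives in this assay 610 nM, and the step of a 2.7-fold lower number from compound 1 to compound 2 (0.42 log units; beyond the scatter) is the only measured one. Compound 3 `COc1cc2c(Oc3ccc(NC(=O)N/N=C/c4ccc(Cl)cc4Cl)cc3F)ccnc2cc1OCCCN1CCC(C)CC1` differs from compound 2 by 2,4-dichlorophenyl in place of 4-nitrophenyl on a carbon with a double bond to nitrogen. Among the measured compounds shown here, no measured step bears directly on this change; the single step from compound 1 to compound 2 touched the same phenyl and was modest, so a change within or only just beyond the scatter is expected, in no fixed direction. Compound 3 is therefore estimated at 320 nM, between 120 nM and 900 nM, a step of a 1.4-fold higher number from compound 2 to compound 3 (0.14 log units; within the scatter).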

Compound 3, half-maximal inhibitory concentration: 470 nM
For compound 3 the middle estimate is 1.5-fold (0.17 log units) below the measured one; the measured number falls inside the stated range.
By their numbers in this assay, from the lowest: compound 2; then compounds 3 and 1 (each within the scatter of the next).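

At the carbon with a double bond to nitrogen, in this assay, 2,4-dichlorophenyl in place of 4-nitrophenyl brings a 2.0-fold higher number from compound 2 to compound 3 (0.31 log units; beyond the scatter) and so shows that 4-nitrophenyl keeps its modest lead over a second replacement, not only over 4-methoxyphenyl. 2,4-dichlorophenyl in place of 4-methoxyphenyl brings a 1.3-fold lower number from compound 1 to compound 3 (0.11 log units; within the scatter) and so does not separate these two groups. Nothing at hand explains either step. The compounds shown leave open how 4-chlorophenyl would compare with 2,4-dichlorophenyl, and whether an amine or a carboxylic acid on this phenyl would match 4-nitrophenyl.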